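The compounds below may be only part of what the source reports. "The series", "measured", "known", "first", "only" and "open" are said of these compounds alone.

In an ADME assay on MRC5 cells (Homo sapiens) for cytotoxicity, read by fluorescence and resazurin assay, with a stated time of 3 days (on this read-out higher numbers stand for an effect only at larger amounts of compound and lower numbers for an effect already at smaller amounts), three compounds have been measured so far. Compound 1 `CC(=O)OC[C@H]1O[C@@H](n2cc(C3(O)C=CC(=O)C=C3)nn2)[C@H](OC(C)=O)[C@@H](OC(C)=O)[C@H]1OC(C)=O` gives > 50000 nM, and this value is a limit of the assay, not a number. Compound 2 `O=C1C=CC(O)(c2cc3ccc(F)cc3n2S(=O)(=O)c2ccccc2)C=C1` gives 170 nM, and compound 3 `O=C1C=CC(O)(c2cc3ccccc3n2S(=O)(=O)c2ccccc2)C=C1` gives 110 nM. Among the compounds with values here, compound 3 therefore stands level with compound 2, the only other compound with a true number here. Placing hydrogen in place of fluoro on an aromatic carbon gives a 1.5-fold lower number from compound 2 to compound 3 (0.19 log units; within the scatter), so these two values cannot be told apart.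

Compound 4 `COC(=O)CCc1ccc(S(=O)(=O)n2c(C3(O)C=CC(=O)C=C3)cc3ccccc32)cc1` keeps the structure of compound 3 but has 2-(methoxycarbonyl)ethyl in place of hydrogen on an aromatic carbon, para to a large group: 2-(methoxycarbonyl)ethyl in place of hydrogen on an aromatic carbon. Within the data shown here, only one measured step offers any guide, namely a 1.5-fold lower number from compound 2 to compound 3 (0.19 log units; within the scatter), and it involved fluoro rather than a chain of this kind. Compound 1 differs too widely from compound 3 to serve as a guide. Among the measured compounds shown here, the data therefore hold no direct precedent for this change, and the one related step stayed small. The expected result is no clear move beyond the scatter, and the direction remains uncertain. The estimated change is a 1.4-fold higher number from compound 3 to compound 4 (0.13 log units; within the scatter). Starting from the value of 110 nM for compound 3, a fairly wide range is warranted. Compound 4 is expected at about 150 nM, within an estimated range from 50 nM to 600 nM.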

Compound 4, half-maximal effective concentration: 280 nM
The estimate for compound 4 lay 1.9-fold (0.27 log units) below the measured number, within the range that was stated.
By their numbers in this assay, from the lowest: compounds 3, 2 and 4 (each within the scatter of the next, the first and the last beyond it). At a limit, above all of these: compound 1.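

Within the data shown here, until now, the only step between measured compounds stayed within the scatter, so nothing showed that a single change to this series could shift the number in this assay. Here, 2-(methoxycarbonyl)ethyl in place of hydrogen, on a six-membered aromatic ring of carbon only and para to a large group, gives a 2.5-fold higher number from compound 3 to compound 4 (0.41 log units; beyond the scatter) as the first step that can be read as a real, though modest, move. This position therefore responds to substitution, yet the chain does not abolish the effect on these cells, since compound 4 still acts at 280 nM in this measurement, and nothing measured here says what lies behind the step.

Among these compounds, with only one group at this position, it stays open whether the length of the chain or the methoxycarbonyl at its end accounts for the step. A carboxylic acid at the end of the same chain, a plain methyl group or an amine in this place could help separate these possibilities, but the compounds shown cannot say how far any of them would move the number.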